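The compounds below may be only part of what the source reports. "The series", "measured", "known", "first", "only" and "open" are said of these compounds alone.

Measured compounds:
Compound 1 `CCOC(=O)N1CCN(CCCOc2ccc(-c3cccs3)cc2)CC1`: 33100 nM
Compound 2 `CC1CCCN(CCCOc2ccc(-c3ccc(C#N)cc3)cc2)C1`: 11700 nM
Compound 3 `CC1CCN(CCCOc2ccc(-c3ccc(C#N)cc3)cc2)CC1`: 9120 nM

In an assay on isolated protein for binding affinity to histamine H2 receptor (Homo sapiens) (a lower number here means a stronger inhibitor, a higher number a weaker inhibitor), compound 1 gives the highest of the three numbers; compound 2 and compound 3 both lie below it by margins beyond the scatter. Compound 4 `CCOC(=O)N1CCN(CCCOc2ccc(-c3ccncc3)cc2)CC1` is drawn from compound 1 by the change (pyridin-4-yl in place of thiophen-2-yl on an aromatic carbon), that is, pyridin-4-yl in place of thiophen-2-yl on an aromatic carbon. Within the data shown here, the only measured step among the three, a 1.3-fold lower number from compound 2 to compound 3 (0.11 log units; within the scatter), alters the saturated ring and not the aryl group, so it does not bear on this change. Among the measured compounds shown here, no measured pair therefore speaks to the size or direction of the move from compound 1 to compound 4, and the expectation is a step of a 1.1-fold lower number from compound 1 to compound 4 (0.04 log units; within the scatter), within the scatter. Compound 4 is thus estimated at 30000 nM, in the range 8000 nM to 100000 nM.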

Compound 4, inhibition constant: 57500 nM
Beside the measured number, compound 4's estimate is 1.9-fold (0.28 log units) below it, within the range that was stated.
By their numbers in this assay, from the lowest: compounds 3 and 2 (each within the scatter of the next); then compounds 1 and 4 (each within the scatter of the next).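

In this assay, among these compounds, pyridin-4-yl in place of thiophen-2-yl on an aromatic carbon, para to a large group, gives a 1.7-fold higher number from compound 1 to compound 4 (0.24 log units; within the scatter) and is the first measured change at this position. With the rest of compound 1 held fixed, a six-membered aromatic ring thus stands where a five-membered one stood, with no step beyond the scatter. No evidence at hand accounts for the step. On these data alone, what pyridin-3-yl or an unsubstituted phenyl group would give at this position remains open. So does whether the same exchange behaves alike on the core of compound 2.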